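A group swap at the limit of the assay

The compounds below may be only part of what the source reports. "The series", "measured", "known", "first", "only" and "open" are said of these compounds alone.

Measured so far in a functional assay on MDA-MB-435 cells (Homo sapiens) for inhibition, read by sulforhodamine B assay, with a stated time of 48 h; on this read-out higher numbers stand for lower toxicity in this test and lower numbers for higher toxicity in this test:
Compound 1 `Cc1ccc(C2=NN(c3ccc(S(C)(=O)=O)cc3)C(=O)CC2)cc1` gives > 100000 nM as a limit
Compound 2 `Cc1cc(O)ccc1C1=NN(c2ccc(S(C)(=O)=O)cc2)C(=O)CC1` gives > 100000 nM as a limit

Compound 2 stands at > 100000 nM here, which is a limit and not a number. Compound 1 likewise stands at > 100000 nM as a limit. The whole picture so far is the limit of > 100000 nM in this assay, at which 2 of the 2 values shown sit, and nothing more.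

Compound 3 `CCc1ccc(C2=NN(c3ccc(S(C)(=O)=O)cc3)C(=O)CC2)cc1` has not yet been measured. It differs from compound 2 in one group, (4-ethylphenyl in place of 4-hydroxy-2-methylphenyl on a carbon with a double bond to nitrogen), with 4-ethylphenyl in place of 4-hydroxy-2-methylphenyl on a carbon with a double bond to nitrogen. Among the measured compounds shown here, the only measured step at this place is a step that the two limits leave unreadable from compound 1 to compound 2 and it offers no size to carry forward. With so little to go on, the estimate is a number no higher from compound 2 to compound 3 (the limit leaves the size open) as the expected move in this assay, with nothing beyond the usual scatter expected and no direction favoured. For compound 3 the expected value is 100000 nM with an estimated range from 40000 nM to 200000 nM and it may well be only a limit again.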

Compound 3, concentration lethal to 50% of the cells: > 100000 nM
Compound 3: no number, only a limit (the forecaster's own chance of this, stated with the estimate: 85%); the middle value sits exactly at the limit.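

The steps among compound 1, compound 2 and compound 3 cannot be read, because all three compounds rest on the same limit and none gives an actual number: the limit of > 100000 nM in this assay, at which 3 of the 3 values shown sit.

In this assay the compounds shown leave open whether 4-methylphenyl, 4-hydroxy-2-methylphenyl and 4-ethylphenyl differ from one another at all.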